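The source may report more compounds than this note shows. Statements on the series, on what has been measured and on what is new or still open speak of the compounds shown alone.

Of the compounds shown here, two have been tested so far in a functional assay on M21 cells (Homo sapiens) for antiproliferative activity, read by sulforhodamine B assay, with a stated time of 48 h; a lower number here means a stronger inhibitor, a higher number a weaker inhibitor. Compound 1 `CCCN1CCN(c2ccc(S(=O)(=O)Oc3ccccc3C)cc2)C1=O` reads > 100000 nM, which is a limit of the assay and not a number. Within the data shown here, compound 2 `CCCN1CCN(c2ccc(S(=O)(=O)Oc3cccc(F)c3)cc2)C1=O` gives 12000 nM, the only true number available. Its standing can be judged only against the limit of compound 1. Among the measured compounds shown here, the one measured step, an at least 8.3-fold lower number from compound 1 to compound 2 (0.92 log units; beyond the scatter), exchanges the group on an oxygen, and it rests on (the limit of > 100000 nM in this assay, at which 1 of the 2 values shown sits), so its full size stays open.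

Compound 3 `CCCCN1CCN(c2ccc(S(=O)(=O)Oc3cccc(F)c3)cc2)C1=O` keeps the 3-fluorophenyl group of compound 2 and alters the chain instead: methyl in place of hydrogen on a saturated chain carbon, three bonds along the chain from an amide-type nitrogen in a ring. In words, this is methyl in place of hydrogen on a saturated chain carbon, three bonds along the chain from an amide-type nitrogen in a ring, which turns propyl into butyl. The step of an at least 8.3-fold lower number from compound 1 to compound 2 (0.92 log units; beyond the scatter) was made at a different place, so it offers no direct guide to this chain. In this assay, no change beyond the scatter is therefore expected, in either direction. The expected change is a 1.2-fold lower number from compound 2 to compound 3 (0.08 log units; within the scatter). Compound 3 is estimated at 10000 nM, with an expected range from 3500 nM to 30000 nM.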

Compound 3, half-maximal inhibitory concentration: > 100000 nM
Compound 3 gave a limit, no number (the forecaster's own chance of this, stated with the estimate: 8%); middle value at least 10-fold (1.00 log units) away from the limit.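

Within this assay this chain position proves sensitive: methyl in place of hydrogen on a saturated chain carbon, which turns propyl into butyl, produces an at least 8.3-fold higher number from compound 2 to compound 3 (0.92 log units; beyond the scatter) and takes the reading from a true number to a limit. Among these compounds, the earlier compounds changed only the group on the oxygen, so this is the first sign that the chain matters as well, and that keeping the 3-fluorophenyl group does not by itself secure a measurable number. On these data alone, the full size of this step stays open because compound 3 sits at a limit of the assay and not at a number: the limit of > 100000 nM in this assay, at which 2 of the 3 values shown sit.

The compounds shown leave open whether a shorter chain such as ethyl, or a propyl chain ending in an amine or a carboxylic acid, would give a lower number than compound 2 does. Among the compounds shown here, it is also open whether butyl would give a measurable number with another group on the oxygen, such as 4-methoxyphenyl, since only one pair of compounds speaks to this chain so far.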